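Chloro scan on the fused core of the series

This account rests on a few compounds, and the source may have more. Where it says the series, first, only, none or still open, it means among the compounds named here.

Compound 1 `O=c1oc(-c2ccccc2I)nc2cccc(Cl)c12`: 3000 nM
Compound 2 `O=c1oc(-c2ccccc2I)nc2ccc(Cl)cc12`: 3000 nM

In an assay on isolated protein for inhibition of complement C1r subcomponent (Homo sapiens) (on this read-out higher numbers stand for weaker inhibition and lower numbers for stronger inhibition), compound 1 gives 3000 nM and compound 2 gives 3000 nM; compound 2 stands level with compound 1 at the digits shown, within the scatter. For the measured compounds named here, no step between measured compounds is available for this assay. Compound 3 `O=c1oc(-c2ccccc2I)nc2cc(Cl)c(Cl)cc12` differs from compound 2 by chloro in place of hydrogen on an aromatic carbon. With compound 1 and compound 2 both sitting at 3000 nM, the expected step for compound 3 is none beyond the scatter, a 1.2-fold lower number from compound 2 to compound 3 (0.08 log units; within the scatter). Compound 3 is therefore estimated at 2500 nM in this assay, with a range from 900 nM to 7000 nM.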

Compound 3, half-maximal inhibitory concentration: 1700 nM
Beside the measured number, compound 3's estimate is 1.5-fold (0.17 log units) above it, and the stated range covers the measured number.
By their numbers in this assay, from the lowest: compounds 3, 1 and 2 (each within the scatter of the next).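

In this assay, chloro in place of hydrogen on an aromatic carbon, ortho to the chloro group of compound 2, gives a 1.8-fold lower number from compound 2 to compound 3 (0.25 log units; within the scatter) and so leaves the read-out unchanged beyond the scatter. The earlier compounds shown here carried a single chloro on the shared core; compound 3 shows that this position accepts a second one without a readable change. No measurement here bears on the reason for this result.

Open, on these data alone, is whether an amine or a carboxylic acid at this position would move the read-out. Also open, as far as these compounds go, is how chloro at this position behaves without the neighbouring chloro group.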